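This account rests on a few compounds, and the source may have more. Where it says the series, first, only, none or still open, it means among the compounds named here.

Three compounds sharing one core, differing only in the length of the chain on the amide, have been tested in a functional assay on HT-29 cells (Homo sapiens) for antiproliferative activity, read by sulforhodamine B assay, with a stated time of 48 h; a higher number here means a weaker inhibitor, a lower number a stronger inhibitor. Compound 1 `CC(=O)Nc1ccc(S(=O)(=O)Oc2ccccc2C(C)C)cc1` gives 23000 nM. Compound 2 `CCC(=O)Nc1ccc(S(=O)(=O)Oc2ccccc2C(C)C)cc1` gives 7400 nM. Compound 3 `CCCC(=O)Nc1ccc(S(=O)(=O)Oc2ccccc2C(C)C)cc1` gives 4900 nM, the lowest of the three numbers; its gap to compound 2 lies within the scatter, while its gap to compound 1 lies beyond it.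

Compound 4 `CCCCCC(=O)Nc1ccc(S(=O)(=O)Oc2ccccc2C(C)C)cc1` carries the chain further: ethyl in place of hydrogen on a saturated chain carbon, three bonds along the chain from a carbonyl carbon. Among the compounds with values here, two measured steps bear on this change. The first lengthening gave a 3.1-fold lower number from compound 1 to compound 2 (0.49 log units; beyond the scatter), and the next gave a 1.5-fold lower number from compound 2 to compound 3 (0.18 log units; within the scatter). Taken together they read a 4.7-fold lower number from compound 1 to compound 3 (0.67 log units; beyond the scatter). The gain shrinks as the chain grows, and the later step already sits within the scatter, so the longer extension in compound 4 is not expected to repeat the early gain. The step is therefore expected to be small and downward in this assay, a 1.6-fold lower number from compound 3 to compound 4 (0.21 log units; within the scatter), and it may not clear the scatter. Compound 4 is accordingly estimated at 3000 nM, with a likely range from 1200 nM to 8000 nM.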

Compound 4, half-maximal inhibitory concentration: 6400 nM
Compound 4: the middle estimate sits 2.1-fold (0.33 log units) below what was measured, within the range that was stated.
By their numbers in this assay, from the lowest: compounds 3, 4 and 2 (each within the scatter of the next); then compound 1.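

Adding ethyl at this place, three bonds along the chain from the carbonyl carbon, gives a 1.3-fold higher number from compound 3 to compound 4 (0.12 log units; within the scatter) in this assay and so brings no change that can be told apart from compound 3. The same holds further back along the series, with a 1.2-fold lower number from compound 2 to compound 4 (0.06 log units; within the scatter) showing that even the longer extension leaves compound 4 level with compound 2. Within the data shown here, only the shortest chain stands apart, with a 3.6-fold lower number from compound 1 to compound 4 (0.56 log units; beyond the scatter) being the one new step that clears the scatter, so the early gain did not continue: among compounds 2, 3 and 4, chain length makes no readable difference, and compound 1 alone goes against that flat picture. Nothing given here accounts for this flat stretch.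

The compounds shown leave open whether a chain longer than the one in compound 4 would stay on this flat stretch, or whether a branched chain such as isopropyl or tert-butyl would read differently. They also leave open what a phenyl ring, an amine or a carboxylic acid on this chain would do to the number, since every chain here is plain and unbranched.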